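Methoxy Substitution on the Aryl Ketone of a Chalcone Series

The compounds below may be only part of what the source reports. "The series", "measured", "known", "first", "only" and "open" are said of these compounds alone.

Measured compounds:
compound 1 `O=C(/C=C/c1cn(-c2ccccc2)nc1-c1ccsc1)c1ccccc1` — 5100 nM
compound 2 `COc1cc(OC)c(C(=O)/C=C/c2cn(-c3ccccc3)nc2-c2ccsc2)c(OC)c1` — 5200 nM

Compound 1 carries an unsubstituted phenyl ring on the carbonyl carbon of the shared core. In a functional assay on HCT-116 cells (Homo sapiens) for inhibition, read by sulforhodamine B assay, with a stated time of 72 h (on this read-out higher numbers stand for weaker inhibition and lower numbers for stronger inhibition), compound 1 gives 5100 nM. Compound 2, which has a trimethoxyphenyl ring at the same place, gives 5200 nM in this assay. The two values lie within the usual scatter of each other, so neither compound can be ranked above the other on these numbers.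

Compound 3 `COc1ccc(OC)c(C(=O)/C=C/c2cn(-c3ccccc3)nc2-c2ccsc2)c1` has not yet been measured. It differs from compound 1 by 2,5-dimethoxyphenyl in place of phenyl on a carbonyl carbon. For the measured compounds named here, only two compounds are known, and their values show that adding methoxy groups on this ring left the read-out essentially unchanged. No step beyond the scatter is therefore expected from compound 1 to compound 3. The value of compound 3 in this assay is estimated at 4500 nM, with a range from 1500 nM to 13000 nM, which corresponds to an expected step of a 1.1-fold lower number from compound 1 to compound 3 (0.05 log units; within the scatter).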

Compound 3, half-maximal inhibitory concentration: 3400 nM
Beside the measured number, compound 3's estimate is 1.3-fold (0.12 log units) above it, and the stated range covers the measured number.
By their numbers in this assay, from the lowest: compounds 3, 1 and 2 (each within the scatter of the next).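

The step of a 1.5-fold lower number from compound 1 to compound 3 (0.18 log units; within the scatter) in this assay lies within the scatter, so 2,5-dimethoxyphenyl cannot be told apart from phenyl on this carbonyl carbon. Compound 2 had already shown this for one methoxy-bearing ring, and compound 3 now shows it for a second ring with a different substitution pattern. No measurement shown here explains why the read-out stays so close across these rings.

As far as these compounds go, it remains open whether any group on this ring can produce a step beyond the scatter, for example an amine, a carboxylic acid or a single fluorine atom in place of the methoxy groups. The compounds also leave open how the read-out responds to changes elsewhere on the shared core, since all three differ only in the ring on the carbonyl carbon.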